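Dithiocarbamate series: thiocarbonyl amine swap, compound 1 to 4

The source may hold more compounds than are shown below. What is called first, only, known or untested is meant among the compounds shown, and "the series" means these compounds.

Three members of this series have numbers in a functional assay on PC-3 cells (Homo sapiens) for antiproliferative activity, read by MTT assay, with a stated time of 72 h; a lower number here means a stronger inhibitor, a higher number a weaker inhibitor. Compound 1 `CCN(CC)C(=S)SCC1=CCOC1=O` gives 57100 nM. Compound 2 `O=C1OCC=C1CSC(=S)N1CCOCC1` gives 48800 nM, and compound 3 `O=C1OCC=C1CSC(=S)Nc1ccccc1` gives 186000 nM. Compound 1 holds the second highest of the three numbers: compound 2 sits nearest, within the scatter, while compound 3 sits furthest, beyond the scatter, with the higher number of the pair.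

Compound 4 `CC(C)NC(=S)SCC1=CCOC1=O` is the next member. It differs from compound 1 in one place, (isopropylamino in place of diethylamino on a thiocarbonyl carbon). Going by the values given here, no step between two measured compounds matches this exchange, so nothing itself fixes its size. The change keeps the shared core untouched and alters only the amine on the thiocarbonyl carbon; the values of compound 1 at 57100 nM and compound 2 at 48800 nM show that one such exchange left the number within the scatter. The step of a 1.2-fold higher number from compound 1 to compound 4 (0.09 log units; within the scatter) is therefore expected to be small, if anything toward a higher number. Compound 4 is expected to give 70000 nM, with a range from 30000 nM to 160000 nM.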

Compound 4, half-maximal inhibitory concentration: 49400 nM
The estimate for compound 4 lay 1.4-fold (0.15 log units) above the measured number, within the range that was stated.
By their numbers in this assay, from the lowest: compounds 2, 4 and 1 (each within the scatter of the next); then compound 3.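

Going by these compounds alone, exchanging diethylamino for isopropylamino on a thiocarbonyl carbon is the first step that can be read directly, and in this assay it gives a 1.2-fold lower number from compound 1 to compound 4 (0.06 log units; within the scatter). The number therefore holds within the scatter when the amine loses one heavy atom and gains a hydrogen-bond donor. An amine hydrogen alone does not accompany the high number: compound 4 has one and gives 49400 nM, and compound 3 also has one and gives 186000 nM in the same assay.

Benzylamino or cyclohexylamino on the thiocarbonyl carbon would help show whether the high number of compound 3 goes with the phenyl group on its amine. No measurement shown gives a cause for the size of this step.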